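A few compounds are considered here, and "the series" means these few. Any claim that something is new, unique, unknown or untested is made for them only; others in the source may bear on it.

Compound 1 `Cc1ccc(SC(=S)N2CCN(C(=O)OC(C)(C)C)CC2)cc1` and compound 2 `Cc1cccc(SC(=S)N2CCN(C(=O)OC(C)(C)C)CC2)c1` share one core and differ only in the methylphenyl group on a sulfur. In a functional assay on A549 cells (Homo sapiens) for antiproliferative activity, read by MTT assay, with a stated time of 72 h (a lower number here means a stronger inhibitor, a higher number a weaker inhibitor), compound 1 gives 2110 nM and compound 2 gives 914 nM, so compound 2 holds the lower, stronger number of the pair.

Compound 3 `Cc1ccccc1SC(=S)N1CCN(C(=O)OC(C)(C)C)CC1` has the same atoms as compound 2, joined differently: 2-methylphenyl in place of 3-methylphenyl on a sulfur. It carries 2-methylphenyl in place of 3-methylphenyl on a sulfur.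

Among the compounds with values here, only one measured step bears on this change, and it is modest: a 2.3-fold lower number from compound 1 to compound 2 (0.36 log units; beyond the scatter). That step came with 3-methylphenyl in place of 4-methylphenyl, which shows that such a swap can move the number in this assay beyond the scatter. Within the data shown here, it cannot show the direction for 2-methylphenyl, which no measured compound carries.

Compound 2 at 914 nM is already the lowest number seen, and the expectation leans slightly upward from it, with a step no larger than the measured one. The expected change is a 1.4-fold higher number from compound 2 to compound 3 (0.15 log units; within the scatter). Compound 3 is estimated at 1300 nM, with an expected range from 550 nM to 3100 nM.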

Compound 3, half-maximal inhibitory concentration: 2270 nM
Compound 3: middle estimate off by 1.7-fold (0.24 log units), on the low side, and the stated range covers the measured number.
By their numbers in this assay, from the lowest: compound 2; then compounds 1 and 3 (each within the scatter of the next).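

In this assay, the swap of 3-methylphenyl for 2-methylphenyl on the sulfur gives (a 2.5-fold higher number from compound 2 to compound 3 (0.40 log units; beyond the scatter)). This settles the direction that the first pair could not show: this swap weakens the compound by about as much as the earlier swap from 3-methylphenyl to 4-methylphenyl strengthened it. The remaining comparison, between 4-methylphenyl and 2-methylphenyl, gives (a 1.1-fold higher number from compound 1 to compound 3 (0.03 log units; within the scatter)), so these two compounds cannot be told apart, and among these three isomers only compound 2, with 3-methylphenyl, stands out as the strongest, with both of its steps beyond the scatter; nothing available explains why this one placement of the methyl group differs from the other two.

These three compounds compare only methyl groups on the phenyl ring, so they cannot say whether the preference for 3-methylphenyl belongs to methyl itself or would also hold for a chlorine atom, a methoxy group or an ethyl group in that place. They also leave open how a plain phenyl group with no methyl at all would compare, which would show whether the methyl group helps at all.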